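A few compounds are considered here, and "the series" means these few. Any claim that something is new, unique, unknown or untested is made for them only; others in the source may bear on it.

Measured compounds:
- compound 1 `O=c1ccoc2cc(OCc3cn(Cc4ccccc4Br)nn3)ccc12` gives 14500 nM
- compound 2 `Cc1ccccc1Cn1cc(COc2ccc3c(=O)ccoc3c2)nn1` gives 15300 nM
- compound 3 `O=c1ccoc2cc(OCc3cn(Cc4cccc([N+](=O)[O-])c4)nn3)ccc12` gives 17300 nM

These three values all come from a functional assay on HeLa cells (Homo sapiens) for cytotoxicity, read by MTT assay, with a stated time of 48 h; on this read-out higher numbers stand for weaker inhibition and lower numbers for stronger inhibition. Compound 1 has the lowest number of the three, but its gap to compound 2 and to compound 3 is small: the step of a 1.1-fold higher number from compound 1 to compound 2 (0.02 log units; within the scatter) and the step of a 1.2-fold higher number from compound 1 to compound 3 (0.08 log units; within the scatter) both sit inside the scatter, so nothing separates the three compounds in this assay. The step of a 1.1-fold higher number from compound 2 to compound 3 (0.05 log units; within the scatter) tells the same story.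

The new compound is compound 4 `COc1ccc(Cn2cc(COc3ccc4c(=O)ccoc4c3)nn2)cc1`. It differs from compound 1 only in the group attached at one place of the shared core: 4-methoxyphenyl in place of 2-bromophenyl on a saturated chain carbon bound to an aromatic nitrogen

Among the compounds with values here, the steps that bear on this change are the ones that swap the same group, the step of a 1.1-fold higher number from compound 1 to compound 2 (0.02 log units; within the scatter) and the step of a 1.2-fold higher number from compound 1 to compound 3 (0.08 log units; within the scatter); both show that changing this part of the molecule, whether to methyl or to a 3-nitrophenyl group, left the number where it was. A 4-methoxyphenyl in this place is therefore expected to behave alike, giving a step of a 1.1-fold higher number from compound 1 to compound 4 (0.04 log units; within the scatter) that stays inside the scatter.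

The estimate for compound 4 in this assay is 16000 nM, expected to fall between 8000 nM and 32000 nM.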

Compound 4, half-maximal inhibitory concentration: 14400 nM
Compound 4: middle estimate off by 1.1-fold (0.05 log units), on the high side, and the stated range covers the measured number.
By their numbers in this assay, from the lowest: compounds 4, 1, 2 and 3 (each within the scatter of the next).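

In this assay, the step of a 1.0-fold lower number from compound 1 to compound 4 (0.00 log units; within the scatter), together with the steps of a 1.1-fold lower number from compound 2 to compound 4 (0.03 log units; within the scatter) and a 1.2-fold lower number from compound 3 to compound 4 (0.08 log units; within the scatter), shows that a fourth ring group on this saturated chain carbon also leaves the compound inseparable from the others. Within the data shown here, the change adds something the earlier compounds did not test, since compound 4 carries a 4-methoxyphenyl group in place of the 2-bromophenyl, 2-methylphenyl and 3-nitrophenyl groups, and the group goes from 0 hydrogen-bond acceptors in 2-bromophenyl to 1 hydrogen-bond acceptor in 4-methoxyphenyl, yet the number stays within the scatter. So among these four compounds, none stands apart, and no measured evidence is available to explain why this position appears so insensitive.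

Going by these compounds, all four compounds keep a substituted phenyl ring on a one-carbon link to the aromatic nitrogen, so it remains open whether a ring bearing an amine or a carboxylic acid would behave the same way. A longer chain between that ring and the nitrogen, or a plain alkyl chain in place of the ring, could also show whether this position stays as flat.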